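The source may hold more compounds than are shown below. What is called first, only, known or untested is meant among the compounds shown, and "the series" means these compounds.

Measured so far in a functional assay on the whole organism for inhibition, with Mus musculus as the target; on this read-out higher numbers stand for an effect only at larger amounts of compound and lower numbers for an effect already at smaller amounts: compound 1 `CCN1CCCC1CNC(=O)c1cc(N(C)S(=O)(=O)N(C)C)ccc1OC` gives 36.2 mg/kg. Compound 2 `CCN1CCCC1CNC(=O)c1cc(NS(C)(=O)=O)ccc1OC` gives only a limit, > 50 mg/kg. Compound 3 `CCN1CCCC1CNC(=O)c1cc(NS(=O)(=O)NC)ccc1OC` likewise gives only a limit, > 50 mg/kg.

Compound 3 thus sits at the edge of this assay, where (the limit of > 50 mg/kg in this assay, at which 2 of the 3 values shown sit); between compound 2 and compound 3 the step that the two limits leave unreadable from compound 2 to compound 3. Compound 4 `CCN1CCCC1CNC(=O)c1cc(N(C)S(N)(=O)=O)ccc1OC` differs from compound 3 by methyl(sulfamoyl)amino in place of (methylsulfamoyl)amino on an aromatic carbon. The measured steps that bear on this are an at least 1.3-fold higher number from compound 1 to compound 2 (0.14 log units; that floor lies within the scatter) and an at least 1.3-fold higher number from compound 1 to compound 3 (0.14 log units; that floor lies within the scatter); both rework the same substituent and both reach only a floor that lies within the scatter. Since the two structures hold the same atoms joined differently, no step beyond the scatter is expected, and another limit is quite possible. Compound 4 is therefore estimated at 45 mg/kg, within 25 mg/kg to 100 mg/kg. That amounts to an expected step of an at least 1.1-fold lower number from compound 3 to compound 4 (0.04 log units; that floor lies within the scatter).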

Compound 4, dose for half-maximal effect: > 50 mg/kg
Compound 4: only a limit was reported; the forecaster's own chance of this, stated with the estimate: 55%; middle value at least 1.1-fold (0.04 log units) away from the limit.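

Compound 4 keeps the methyl on the nitrogen at the aromatic carbon, as compound 1 does, yet it gives only a limit, so that methyl alone does not secure a readable value. Amino in place of dimethylamino on the sulfonyl sulfur gives an at least 1.3-fold higher number from compound 1 to compound 4 (0.14 log units; that floor lies within the scatter). The steps among compound 2, compound 3 and compound 4 cannot be read, because all three stand at one limit: the limit of > 50 mg/kg in this assay, at which 3 of the 4 values shown sit.

Left open is how far past that limit these three compounds lie. Also open, on these data alone, is whether methylamino on the sulfonyl sulfur, with that nitrogen methyl kept, would give a readable value.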